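Methoxy to methyl on the amide aryl ring

A few compounds are considered here, and "the series" means these few. Any claim that something is new, unique, unknown or untested is made for them only; others in the source may bear on it.

compound 1, `O=C(Nc1cccc(-c2oc3cc(-c4ccc(F)cc4)ccc3c(=O)c2O)c1)c1ccccc1F`: in a functional assay on HepG2 cells (Homo sapiens) for antiproliferative activity, read by CCK-8 assay, with a stated time of 72 h (on this read-out lower numbers stand for stronger inhibition and higher numbers for weaker inhibition), compound 1 gives 10100 nM
compound 2, `COc1cccc(C(=O)Nc2cccc(-c3oc4cc(-c5ccc(F)cc5)ccc4c(=O)c3O)c2)c1`: in this assay compound 2 gives 9950 nM

Compound 2 holds the lower of the two numbers, but the step of a 1.0-fold lower number from compound 1 to compound 2 (0.01 log units; within the scatter) lies within the scatter, so no order between the two is claimed. Compound 3, `Cc1cccc(C(=O)Nc2cccc(-c3oc4cc(-c5ccc(F)cc5)ccc4c(=O)c3O)c2)c1`, differs from compound 2 by methyl in place of methoxy on an aromatic carbon. For the measured compounds named here, the only measured step, a 1.0-fold lower number from compound 1 to compound 2 (0.01 log units; within the scatter), changed this same aryl ring with no shift beyond the scatter, and it is the one step that bears on the new change. No step beyond the scatter is therefore expected; for compound 3 the step of a 1.0-fold higher number from compound 2 to compound 3 (0.00 log units; within the scatter) is estimated, giving 10000 nM with a range of 4500 nM to 22000 nM.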

Compound 3, half-maximal inhibitory concentration: 13500 nM
For compound 3 the middle estimate is 1.4-fold (0.13 log units) below the measured one, and the stated range covers the measured number.
By their numbers in this assay, from the lowest: compounds 2, 1 and 3 (each within the scatter of the next).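

In this assay, methyl in place of methoxy gives a 1.4-fold higher number from compound 2 to compound 3 (0.13 log units; within the scatter), so at this place on the amide aryl ring the methoxy oxygen is not required to stay within the scatter. Set against the 2-fluorophenyl amide, the 3-methylphenyl amide gives a 1.3-fold higher number from compound 1 to compound 3 (0.13 log units; within the scatter), which places all three aryl groups on the carbonyl within the scatter of one another. Nothing at hand offers an explanation for these numbers.

On these data alone, whether any group on this ring can move the number beyond the scatter stays open. An amine, a carboxylic acid or a longer chain at this place would test that.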